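The source may hold more compounds than are shown below. What is called first, only, known or untested is meant among the compounds shown, and "the series" means these compounds.

The measured compounds:
Compound 1, `O=C(/C=C/c1coc2cc(O)ccc2c1=O)NCc1ccccc1`. In a functional assay on A549 cells (Homo sapiens) for inhibition, read by MTT assay, with a stated time of 48 h (a higher number here means a weaker inhibitor, a lower number a stronger inhibitor), compound 1 reaches only the limit > 100000 nM.
Compound 2, `COc1ccc2c(=O)c(/C=C/C(=O)NCc3ccccc3F)coc2c1`. In this assay compound 2 likewise stops at the limit > 100000 nM.
Compound 3, `Cc1ccccc1NC(=O)/C=C/c1coc2cc(O)ccc2c1=O`. In this assay compound 3 also gives only the limit > 100000 nM.

Compound 2 therefore stands at the limit of this assay, and it shares that position with both other measured compounds, since (the limit of > 100000 nM in this assay, at which 3 of the 3 values shown sit). For the measured compounds named here, the only step between two measured compounds is a step that the two limits leave unreadable from compound 1 to compound 3, and it stays unreadable because of the limit of > 100000 nM in this assay, at which 3 of the 3 values shown sit.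

The unmeasured compound 4, `CCOc1ccc(NC(=O)/C=C/c2coc3cc(OC)ccc3c2=O)cc1`, arises from compound 2 by 4-ethoxyphenyl in place of 2-fluorobenzyl on an amide-type nitrogen. The nearest measured step, a step that the two limits leave unreadable from compound 1 to compound 3, likewise replaces a benzyl by a substituted phenyl on the amide-type nitrogen, yet its size cannot be read, so no direction for the change in this assay can be taken from it.

Compound 4 is thus expected to sit at or near the limit as well, with an estimated step that the limit leaves unreadable from compound 2 to compound 4. The estimate for compound 4 in this assay is 120000 nM, within a range from 30000 nM to 500000 nM.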

Compound 4, half-maximal inhibitory concentration: > 100000 nM
Compound 4: a limit, no number (the forecaster's own chance of this, stated with the estimate: 85%); the middle value does not contradict the limit.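

For the compounds shown here, compound 2 and compound 4 both stop at a limit, so no step between them can be read: the limit of > 100000 nM in this assay, at which 4 of the 4 values shown sit. The compounds shown leave open whether any change on the amide-type nitrogen alters inhibition in this assay at all.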